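Swapping the aryl group of compound 2: a permeability outlook

This account rests on a few compounds, and the source may have more. Where it says the series, first, only, none or still open, it means among the compounds named here.

Compound 2 `Cc1oc(-c2ccc(Cl)cc2)nc1CN1CCC(C(=O)NCCCN2C[C@H](C)C[C@H](C)C2)CC1` was run in a physicochemical assay for permeability, using PAMPA; on this read-out lower numbers stand for lower permeability and higher numbers for higher permeability. For compound 2 the result is only a limit, > 635 10^-6 cm/s, not a number; it is the limit of > 635 10^-6 cm/s in this assay, at which 1 of the 3 values shown sits. Two other compounds carry a different aryl group on the shared core. In this assay compound 1 `Cc1ccccc1-c1nc(CN2CCC(C(=O)NCCCN3CCC(C(C)C)CC3)CC2)c(C)o1` gives 396 10^-6 cm/s, and compound 3 `Cc1ccccc1-c1nc(CN2CCC(C(=O)NCCCN3CC4CCCC(C4)C3)CC2)c(C)o1` gives 331 10^-6 cm/s. These two differ by one exchanged group, and the step of a 1.2-fold lower number from compound 1 to compound 3 (0.08 log units; within the scatter) shows that this exchange makes no difference beyond the scatter.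

Compound 4 `COc1cccc(C)c1-c1nc(CN2CCC(C(=O)NCCCN3C[C@H](C)C[C@H](C)C3)CC2)c(C)o1` differs from compound 2 in 2-methoxy-6-methylphenyl in place of 4-chlorophenyl on an aromatic carbon. For the measured compounds named here, no measured step changes the group at this place, so the only measured step offers no direct guide, and all three measured compounds sit high in this assay. Compound 4 is therefore expected to stay in that high region, with an estimate of 450 10^-6 cm/s, ranging from 250 10^-6 cm/s to 700 10^-6 cm/s. The step this estimate implies is an at least 1.4-fold lower number from compound 2 to compound 4 (0.14 log units; that floor lies within the scatter), a move expected rather than measured.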

Compound 4, apparent permeability: 198 10^-6 cm/s
Estimate against measurement, compound 4: 2.3-fold (0.36 log units) above, outside the stated range (below it).
By their numbers in this assay, from the lowest: compounds 4, 3 and 1 (each within the scatter of the next). At a limit, above all of these: compound 2.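

In this assay, for the compounds shown here, this is the first measured step at the aromatic carbon that carries the aryl group, and it reads an at least 3.2-fold lower number from compound 2 to compound 4 (0.50 log units; beyond the scatter). The earlier step changed a different part of the molecule and stayed within the scatter, whereas exchanging 4-chlorophenyl for 2-methoxy-6-methylphenyl moves the number beyond it, so this position is not silent on this read-out. Compound 2 gives a limit rather than a number, so the size of this step is known only as a floor: the limit of > 635 10^-6 cm/s in this assay, at which 1 of the 4 values shown sits.

The exchange removes the chlorine and adds a methoxy and a methyl group in one move, so the compounds shown do not tell which of these changes matters. An aryl group carrying only the methoxy, only the methyl, or an amine instead would be needed to separate these contributions.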